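The source may report more compounds than this note shows. Statements on the series, on what has been measured and on what is new or still open speak of the compounds shown alone.

Working notes on the series. In a functional assay on ECV-304 cells (Homo sapiens) for cytotoxicity (a lower number here means a stronger inhibitor, a higher number a weaker inhibitor), compound 1 `O=C1/C(=C/c2ccc([N+](=O)[O-])cc2)SC(=S)N1NS(=O)(=O)c1ccccc1` gives > 50000 nM as a limit and not a number. Compound 2 `N#Cc1ccc(/C=C2\SC(=S)N(NS(=O)(=O)c3ccccc3)C2=O)cc1` gives > 50000 nM as a limit too, and that limit is all that is known of where it stands. Going by the values given here, the only measured step that the two limits leave unreadable from compound 1 to compound 2 has no readable size, and the limit of > 50000 nM in this assay, at which 2 of the 2 values shown sit, sums up the evidence so far. Compound 3 `O=C1/C(=C/c2ccc(Cl)c(Cl)c2)SC(=S)N1NS(=O)(=O)c1ccccc1` differs from compound 2 by 3,4-dichlorophenyl in place of 4-cyanophenyl on a double-bonded chain carbon bound to a double-bonded ring carbon with 3,4-dichlorophenyl in place of 4-cyanophenyl on a double-bonded chain carbon bound to a double-bonded ring carbon. Among the compounds with values here, no measured step gives a size for this change, so the expected move in this assay is modest and toward stronger inhibition, with the estimated step of an at least 1.2-fold lower number from compound 2 to compound 3 (0.09 log units; that floor lies within the scatter) resting on no sized precedent. For compound 3 the estimate is 40000 nM with an expected range from 12000 nM to 120000 nM in this series.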

Compound 3, half-maximal inhibitory concentration: > 50000 nM
Compound 3: no number, only a limit; the forecaster's own chance of this, stated with the estimate: 55%; at least 1.2-fold (0.09 log units) between middle value and limit.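

Going by these compounds alone, compound 3 also gives only a limit, so no step among compound 1, compound 2 and compound 3 can be read. The compounds shown leave open how far these groups differ in this assay, as all three compounds sit at one limit: the limit of > 50000 nM in this assay, at which 3 of the 3 values shown sit.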